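Swapping the amide aryl: from chloro-methyl to trimethyl

A few compounds are considered here, and "the series" means these few. Any claim that something is new, unique, unknown or untested is made for them only; others in the source may bear on it.

The two measured compounds share a core and differ in two places. Compound 1 `COc1cc2c(Nc3nc4ccc(C(=O)Nc5c(C)cc(C)cc5C)cc4s3)ncnc2cc1OCCCN1CCC(C)CC1` gives 7000 nM in a functional assay on DLD-1 cells (Homo sapiens) for cytotoxicity, read by WST assay, with a stated time of 72 h; a lower number here means a stronger inhibitor, a higher number a weaker inhibitor. Compound 2 `COc1cc2c(Nc3nc4ccc(C(=O)Nc5c(C)cccc5Cl)cc4s3)ncnc2cc1OCCCN1CCCC1` gives 60700 nM in this assay, the higher of the two numbers and well beyond the scatter from compound 1. Compound 3 `COc1cc2c(Nc3nc4ccc(C(=O)Nc5c(C)cc(C)cc5C)cc4s3)ncnc2cc1OCCCN1CCCC1` has not been measured; it keeps the amine-bearing chain of compound 2 and changes only the aryl on the amide, (2,4,6-trimethylphenyl in place of 2-chloro-6-methylphenyl on an amide-type nitrogen). Among the measured compounds shown here, no single-change step between measured compounds exists here, so the size of this change is not known directly. Compound 3 is expected to move toward compound 1, which bears the same entering group and gives 7000 nM, with a step from compound 2 to compound 3 of about a 3.4-fold lower number from compound 2 to compound 3 (0.53 log units; beyond the scatter) toward a lower number, beyond the scatter. Compound 3 is therefore estimated at 18000 nM, within 6000 nM to 50000 nM.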

Compound 3, half-maximal inhibitory concentration: 5900 nM
Estimate against measurement, compound 3: 3.1-fold (0.48 log units) above, and the stated range ends above it.
By their numbers in this assay, from the lowest: compounds 3 and 1 (each within the scatter of the next); then compound 2.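

In this assay, the aryl on the amide now has a step of its own: 2,4,6-trimethylphenyl in place of 2-chloro-6-methylphenyl gives a 10-fold lower number from compound 2 to compound 3 (1.01 log units; beyond the scatter) and is a large change at this amide-type nitrogen. Among the compounds shown here, the amine at the end of the chain can also be read alone for the first time, and pyrrolidin-1-yl in place of 4-methylpiperidin-1-yl gives a 1.2-fold lower number from compound 1 to compound 3 (0.07 log units; within the scatter) so these two amines cannot be told apart in this measurement. Nothing available here gives a reason for the large step on the amide aryl.

On these data alone, it remains open whether a 2,6-dimethylphenyl or a 2,6-dichlorophenyl on the amide would read with compound 3 or with compound 2. As far as these compounds go, it is equally open whether a morpholine at the end of the chain would stay within the scatter of pyrrolidin-1-yl.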